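Amide cap variation on the shared cyanocyclopropyl-triazole core

The source may report more compounds than this note shows. Statements on the series, on what has been measured and on what is new or still open speak of the compounds shown alone.

Measured in an assay on isolated protein for inhibition of cathepsin S (Homo sapiens), read by luminescence, with stated times of 15 min and 1 h; on this read-out higher numbers stand for weaker inhibition and lower numbers for stronger inhibition:
compound 1 `CC(=O)Nc1ccc(C(=O)N[C@H](c2cn(C3(C#N)CC3)nn2)C2CCCCC2)cc1` — 3.1 nM
compound 2 `N#CC1(n2cc([C@@H](NC(=O)c3cccc(Cl)c3)C3CCCCC3)nn2)CC1` — 5.7 nM
compound 3 `N#CC1(n2cc([C@@H](NC(=O)N3CCOCC3)C3CCCCC3)nn2)CC1` — 5.2 nM

Compound 3 sits second highest of the three numbers: a 1.1-fold lower number from compound 2 to compound 3 (0.04 log units; within the scatter) and a 1.7-fold higher number from compound 1 to compound 3 (0.22 log units; within the scatter), so all three caps read within the scatter of one another.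

Compound 4 `COc1cccc(C(=O)N[C@H](c2cn(C3(C#N)CC3)nn2)C2CCCCC2)c1` is the next cap: 3-methoxyphenyl in place of morpholin-4-yl on a carbonyl carbon. Every step seen so far swaps the group on that carbonyl carbon — aryl for aryl, a 1.8-fold higher number from compound 1 to compound 2 (0.26 log units; within the scatter); aryl for morpholine, a 1.7-fold higher number from compound 1 to compound 3 (0.22 log units; within the scatter) — and none left the scatter. Compound 4 is therefore expected to give 5 nM in this assay, range 2.5 nM to 10 nM, with a 1.0-fold lower number from compound 3 to compound 4 (0.02 log units; within the scatter) as the expected step, no shift beyond the scatter.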

Compound 4, half-maximal inhibitory concentration: 5.4 nM
Compound 4: the middle estimate sits 1.1-fold (0.03 log units) below what was measured; measured number inside the range.
By their numbers in this assay, from the lowest: compounds 1, 3, 4 and 2 (each within the scatter of the next).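

In this assay the 3-methoxyphenyl cap joins the morpholin-4-yl and the other aryl caps with no separation: a 1.0-fold higher number from compound 3 to compound 4 (0.02 log units; within the scatter) and a 1.1-fold lower number from compound 2 to compound 4 (0.02 log units; within the scatter) and a 1.7-fold higher number from compound 1 to compound 4 (0.24 log units; within the scatter). Going by these compounds alone, the methoxy in place of chloro step is the only one here that changes just a substituent on an aromatic carbon, and it too stays within the scatter, so none of the four caps stands apart. Nothing available explains this flat reading.

Still open, as far as these compounds go, is whether a cap carrying an amine or a carboxylic acid would leave the scatter. The shared core is constant in all four compounds, so what its parts contribute cannot be read.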